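Acid to Amide on a Shared Core

A few compounds are considered here, and "the series" means these few. Any claim that something is new, unique, unknown or untested is made for them only; others in the source may bear on it.

Compound 3 `COc1ccc(-c2cc(-c3ccc(C(=O)O)cc3)cnc2N)cn1` gives 0.8 in a physicochemical assay for lipophilicity, at pH 7.4 (on this read-out lower numbers stand for lower lipophilicity and higher numbers for higher lipophilicity), the lowest of the three numbers recorded. Compound 1 `COc1ccc(-c2cc(-c3ccc(S(N)(=O)=O)cc3)cnc2N)cn1` gives 1.8, and compound 2 `COc1ccc(-c2cc(-c3ccc(-n4cccn4)cc3)cnc2N)cn1` gives 3.1. The steps of a number 1.00 log units lower from compound 1 to compound 3 (beyond the scatter) and a number 2.30 log units lower from compound 2 to compound 3 (beyond the scatter) set compound 3 well apart from the other two, and the step of a number 1.30 log units higher from compound 1 to compound 2 (beyond the scatter) completes the set. Compound 4 `COc1ccc(-c2cc(-c3ccc(C(N)=O)cc3)cnc2N)cn1` differs from compound 3 by amino in place of hydroxy on a carbonyl carbon. Among the measured compounds shown here, no measured step swaps hydroxy for amino; the measured steps exchange whole groups and bear only loosely on this change. Because compound 1 with its sulfamoyl gives 1.8 in this assay, a carbamoyl is expected to land near that level. Compound 4 is therefore expected at 1.9, within 1.3 to 2.5. The expected step is a number 1.10 log units higher from compound 3 to compound 4 (beyond the scatter).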

Compound 4, distribution coefficient: 1.7
The estimate for compound 4 lay 0.20 log units above the measured number, within the range that was stated.
By their numbers in this assay, from the lowest: compound 3; then compounds 4 and 1 (each within the scatter of the next); then compound 2.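

In this assay, among the compounds shown here, the change on the carbonyl carbon gives a number 0.90 log units higher from compound 3 to compound 4 (beyond the scatter), the first measured step that exchanges only hydroxy for amino rather than a whole group. At this aromatic carbon, carbamoyl and sulfamoyl cannot be told apart, with a number 0.10 log units lower from compound 1 to compound 4 (within the scatter), whereas a number 1.40 log units lower from compound 2 to compound 4 (beyond the scatter) separates 1H-pyrazol-1-yl from carbamoyl. The compounds shown leave open where a nitrile or a methyl ester would fall at this aromatic carbon, and whether the same exchange on a carbonyl carbon gives a similar step on another core. No evidence given here accounts for these steps.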